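From 3-bromophenyl to 4-cyanophenyl: compound 2 and compound 3

A few compounds are considered here, and "the series" means these few. Any claim that something is new, unique, unknown or untested is made for them only; others in the source may bear on it.

Compound 1 `COc1cc2ncnc(Nc3ccc(F)c(Cl)c3)c2cc1NC(=O)N/N=C/c1ccc(F)cc1` gives 31100 nM
Compound 2 `COc1cc2ncnc(Nc3ccc(F)c(Cl)c3)c2cc1NC(=O)N/N=C/c1cccc(Br)c1` gives "not active" (no number reported)

Both compounds share one core and were tested in a functional assay on HepG2 cells (Homo sapiens) for cytotoxicity, read by MTT assay, with a stated time of 72 h (on this read-out lower numbers stand for stronger inhibition and higher numbers for weaker inhibition), on the same cells. Compound 2 has no place on the numerical scale, since compound 2 was reported as "not active" (no number reported) and no single number exists for it. Among the compounds with values here, the only number so far belongs to compound 1, which gave 31100 nM in this assay as its reading.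

Compound 3 `COc1cc2ncnc(Nc3ccc(F)c(Cl)c3)c2cc1NC(=O)N/N=C/c1ccc(C#N)cc1` is the next to be measured. It departs from compound 2 as follows: 4-cyanophenyl in place of 3-bromophenyl on a carbon with a double bond to nitrogen. In words, this places 4-cyanophenyl in place of 3-bromophenyl on a carbon with a double bond to nitrogen.

Within the data shown here, no measured step between compounds differing in one place is available to size this change. A large gain in this assay is therefore not expected, and any step is expected to be modest and of uncertain direction. A report with no number remains possible.

The estimated value for compound 3 is 35000 nM with an expected range from 12000 nM to 100000 nM in this estimate.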

Compound 3, half-maximal inhibitory concentration: 34100 nM
Estimate against measurement, compound 3: 1.0-fold (0.01 log units) above; low and high end bracket the measured number.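

In this assay, within the data shown here, the aromatic group on the carbon with a double bond to nitrogen can now be sized for the first time, and the step is a 1.1-fold higher number from compound 1 to compound 3 (0.04 log units; within the scatter). Cyano in place of fluoro on an aromatic carbon therefore leaves the reading within the usual scatter, and the number stays in the same range, while the step between compound 2, reported as "not active" with no number, and compound 3 cannot be read. Nothing available accounts for these readings or for the missing number of compound 2.

The compounds shown do not separate the identity of the group from its place on the ring, since 3-bromophenyl and 4-cyanophenyl differ in both, and a 4-bromophenyl or 3-cyanophenyl partner would be needed to tell the two apart. They also leave open whether an amine or a carboxylic acid on this ring, or a longer chain in place of the ring, would give a step beyond the scatter in this assay.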